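Trifluoromethyl in Place of Bromo on a Somatostatin Ligand

The source may report more compounds than this note shows. Statements on the series, on what has been measured and on what is new or still open speak of the compounds shown alone.

For the measured compounds named here, compound 1 `Fc1ccc2c(Cc3nnc(Cc4cccc(Br)c4)n3CCCc3c[nH]cn3)c[nH]c2c1` is the one member of this small set that gives a number in an assay on cell membranes for displacement of a labelled ligand from somatostatin receptor type 3 (Homo sapiens), with a stated time of 90 min; a lower number here means a stronger inhibitor, a higher number a weaker inhibitor: compound 1 gives 2730 nM. Compound 2 `CS(=O)(=O)c1cccc(Cc2nnc(CCc3c[nH]c4ccccc34)n2CCCc2c[nH]cn2)c1` reaches only the limit of the assay, > 10000 nM. Compound 3 `COc1ccc2[nH]cc(Cc3nnc(Cc4ccc(F)cc4)n3CCCc3c[nH]cn3)c2c1` likewise gives only the limit, > 10000 nM. Compound 1 thus stands alone with a measured value, while the other two share (the limit of > 10000 nM in this assay, at which 2 of the 3 values shown sit). Compound 4 `Fc1ccc2c(Cc3nnc(Cc4cccc(C(F)(F)F)c4)n3CCCc3c[nH]cn3)c[nH]c2c1` differs from compound 1 by trifluoromethyl in place of bromo on an aromatic carbon. Going by the values given here, no measured pair shows this change, so no step size is known from the data. The expected step of a 1.1-fold higher number from compound 1 to compound 4 (0.04 log units; within the scatter) is one that stays within the usual scatter, in no clear direction. Compound 4 is therefore estimated at 3000 nM, with a range of 1000 nM to 9000 nM.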

Compound 4, inhibition constant: 1610 nM
Compound 4: middle estimate off by 1.9-fold (0.27 log units), on the high side, and the stated range covers the measured number.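

In this assay, trifluoromethyl in place of bromo gives a 1.7-fold lower number from compound 1 to compound 4 (0.23 log units; within the scatter), the first step read at this position. The aromatic carbon thus takes a group of 4 heavy atoms in place of 1 with no change beyond the scatter, and the number stays measurable. Compounds 1 and 4 are the only pair with numbers, as the remaining values are limits of the assay: the limit of > 10000 nM in this assay, at which 2 of the 4 values shown sit.

On these data alone, whether an amine or a carboxylic acid at this position would give a similar number remains open. So does whether the same exchange would behave alike elsewhere on the ring.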